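Triazolyl-aryl variation on the spiro core: antiproliferative limits

A few compounds are considered here, and "the series" means these few. Any claim that something is new, unique, unknown or untested is made for them only; others in the source may bear on it.

Measured compounds in a functional assay on MCF7 cells (Homo sapiens) for antiproliferative activity, read by MTT assay, with a stated time of 48 h; a higher number here means a weaker inhibitor, a lower number a stronger inhibitor:
- compound 1 `CCOc1ccccc1-n1nncc1CN1C(=O)C2(C(C#N)=C(N)Oc3c(N)cc4nc5ccccc5nc4c32)c2ccccc21`, > 50000 nM
- compound 2 `N#CC1=C(N)Oc2c(N)cc3nc4ccccc4nc3c2C12C(=O)N(Cc1cnnn1-c1ccc([N+](=O)[O-])cc1)c1ccccc12`, > 50000 nM
- compound 3 `N#CC1=C(N)Oc2c(N)cc3nc4ccccc4nc3c2C12C(=O)N(Cc1cnnn1-c1ccc(Cl)cc1Cl)c1ccccc12`, > 50000 nM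

Every value in this assay is a limit of the assay and not a number. Compound 3 stands only at a limit, and so do the two other compounds shown, as recorded in the limit of > 50000 nM in this assay, at which 3 of the 3 values shown sit. The changes among the measured compounds all fall on the aryl group attached to an aromatic nitrogen of the shared core: a step that the two limits leave unreadable from compound 1 to compound 2, a step that the two limits leave unreadable from compound 1 to compound 3 and a step that the two limits leave unreadable from compound 2 to compound 3, none of which can be read, since both ends of each step sit at the limit.

Compound 4 `COc1cc(-n2nncc2CN2C(=O)C3(C(C#N)=C(N)Oc4c(N)cc5nc6ccccc6nc5c43)c3ccccc32)c(OC)cc1Cl` is not yet measured. It differs from compound 3 as follows: 4-chloro-2,5-dimethoxyphenyl in place of 2,4-dichlorophenyl on an aromatic nitrogen. All three measured steps bear on this change, as they vary the same aryl group at the same place, and each of them left the limit unmoved. Going by the values given here, no step of readable size is therefore expected, and the expected step that the limit leaves unreadable from compound 3 to compound 4 is none beyond the scatter. Compound 4 is expected to give 60000 nM, with a range from 20000 nM to 200000 nM, most likely again reported as a limit.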

Compound 4, half-maximal inhibitory concentration: > 50000 nM
Compound 4: no number, only a limit; the forecaster's own chance of this, stated with the estimate: 85%; the middle value does not contradict the limit.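

In this assay compound 4 gives > 50000 nM, a limit of the assay and not a number. Its steps to compound 1, compound 2 and compound 3 cannot be read, since all four compounds sit at one limit: the limit of > 50000 nM in this assay, at which 4 of the 4 values shown sit.

Which aryl group on the shared core, if any, gives a measurable value remains open.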